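The compounds below may be only part of what the source reports. "The series", "measured", "known", "first", "only" and "open" are said of these compounds alone.

Working notes on the series. Two compounds carry numbers in an assay on isolated protein for inhibition of protein deacetylase HDAC6 (Homo sapiens), read by fluorescence, with a stated time of 1 h, tested at 100 nM; on this read-out higher numbers stand for more inhibition at the one concentration tested (going by the name of the read-out) and lower numbers for less inhibition. Compound 1 `COc1ccc(CN2CCC(c3noc(COc4ccc(/C=C/C(=O)NO)cc4)n3)CC2)cc1` gives 75% in this assay. Compound 2 `CN(Cc1nc(C2CCN(Cc3ccc(F)cc3)CC2)no1)c1ncc(C(=O)NO)cn1` gives 65% in this assay; its number and that of compound 1 lie within the scatter of each other, so the two are not told apart on this read-out. For the measured compounds named here, no step between compounds that differ in one place has been measured, so no step size is known for any single change here.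

Compound 3 `CN(Cc1nc(C2CCN(Cc3ccc(F)cc3Cl)CC2)no1)c1ncc(C(=O)NO)cn1` has not yet been measured in this assay. It differs from compound 2 by chloro in place of hydrogen on an aromatic carbon. Going by the values given here, with no measured step on which to rest a direction, the expectation is for no change beyond the scatter, a step of no change at the digits printed from compound 2 to compound 3 (within the scatter) from the number of compound 2. Compound 3 is therefore estimated at 65% in this assay, with a range of 45% to 82%.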

Compound 3, a percentage reported as inhibition, at one concentration (the size of the read-out at that concentration, not a potency): 49%
The estimate for compound 3 lay 16 percentage points above the measured number, and the stated range covers the measured number.
By their numbers in this assay, from the lowest: compound 3; then compounds 2 and 1 (each within the scatter of the next).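

In this assay, the series now has its first step between compounds that differ in one place: going from 4-fluorobenzyl to 2-chloro-4-fluorobenzyl gives a number 16 percentage points lower from compound 2 to compound 3 (beyond the scatter). This shows that the aromatic carbon ortho to a large group and meta to the fluoro group is not indifferent on this read-out, as chloro in place of hydrogen there goes with less inhibition at the one concentration tested. Nothing at hand bears on the reason for this step.

On these data alone, it remains open whether the step is particular to chloro or would also appear with a methyl group or an amino group on the same carbon. Also open, as far as these compounds go, is how chloro would read on a different carbon of this ring.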